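The compounds below may be only part of what the source reports. "The series", "measured", "known", "first", "only" and "open" are said of these compounds alone.

Measured compounds:
- compound 1 `COc1ccc(-c2cn([C@@H]3C[C@H](CO)N(C)O3)nn2)cc1`: 7180 nM
- compound 2 `CCCCCc1ccc(-c2cn([C@@H]3C[C@H](CO)N(C)O3)nn2)cc1`: 6240 nM

Both compounds share a core and differ only in the group on the aromatic ring. In a functional assay on 8305C cells (Homo sapiens) for cytotoxicity, read by MTT assay, with a stated time of 24 h (a higher number here means a weaker inhibitor, a lower number a stronger inhibitor), compound 1 gives 7180 nM and compound 2 gives 6240 nM. Of the two numbers, compound 2 gives the lower one, but the gap is within the scatter, so the two stand together rather than apart: a 1.2-fold lower number from compound 1 to compound 2 (0.06 log units; within the scatter).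

Compound 3 `CN1O[C@H](n2cc(-c3ccc(F)cc3)nn2)C[C@@H]1CO` is not yet measured. It differs from compound 2 by fluoro in place of pentyl on an aromatic carbon. Among the compounds with values here, the single measured step that bears on this is the one from compound 1 to compound 2, which also swapped the group at the same place and was a 1.2-fold lower number from compound 1 to compound 2 (0.06 log units; within the scatter). Within the data shown here, that step is the only guide, and it showed no movement beyond the scatter when a small group gave way to a five-carbon chain. A further swap at the same position, now to fluoro, is therefore expected to give no step beyond the scatter in this assay, in either direction: a 1.1-fold higher number from compound 2 to compound 3 (0.04 log units; within the scatter). Compound 3 is expected to give 6800 nM, with a range from 3000 nM to 15000 nM.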

Compound 3, half-maximal inhibitory concentration: 6850 nM
Beside the measured number, compound 3's estimate is 1.0-fold (0.00 log units) below it; measured number inside the range.
By their numbers in this assay, from the lowest: compounds 2, 3 and 1 (each within the scatter of the next).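

In this assay, methoxy, pentyl and fluoro have now been compared on the same aromatic carbon, para to a large group, and the new steps stay within the scatter: a 1.1-fold higher number from compound 2 to compound 3 (0.04 log units; within the scatter), and a 1.0-fold lower number from compound 1 to compound 3 (0.02 log units; within the scatter). Within the data shown here, the earlier pair gave only one swap at this place, whereas these three compounds form a set in which no pair stands apart, so the reading no longer rests on a single step. The range of entering groups now runs from fluoro, with 1 heavy atom, to pentyl, with 5 heavy atoms, and across compounds 1, 2 and 3 that range comes with no step beyond the scatter, though no measurement given here offers an explanation for this flat reading.

As far as these compounds go, whether an amine, a carboxylic acid or a chain longer than pentyl at this aromatic carbon would give a step beyond the scatter remains open. Also open, from the compounds shown here alone, is whether swaps at this place stay equally flat when another part of the shared core is changed.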